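A few compounds are considered here, and "the series" means these few. Any claim that something is new, unique, unknown or untested is made for them only; others in the source may bear on it.

Measured compounds:
compound 1, `CCCCCc1cn(C/C=C(/C)CCC=C(C)C)nn1`, in a physicochemical assay for lipophilicity, measured as octanol-water partition (on this read-out higher numbers stand for higher lipophilicity and lower numbers for lower lipophilicity), gives 5.45;
compound 2, `CCCCCCCCc1cn(C/C=C(/C)CCC=C(C)C)nn1`, in this assay gives 6.92;
compound 3, `CCCc1cn(C/C=C(/C)CC/C=C(\C)CCC=C(C)C)nn1`, in this assay gives 6.5.

Compound 3 stands second highest of the three numbers, beyond the scatter above compound 1 and beyond the scatter below compound 2. Compound 4, `CCCc1cn(C/C=C(/C)CCC=C(C)C)nn1`, has not yet been measured. It differs from compound 3 in one place: hydrogen in place of 3-methylbut-2-en-1-yl on a saturated chain carbon bound to a double-bonded chain carbon. Among the measured compounds shown here, the one measured step that bears on this is a number 1.47 log units higher from compound 1 to compound 2 (beyond the scatter), a large rise for three added chain carbons. The change to compound 4 removes more carbons than that step added, so a large fall in this assay is expected. Compound 4 is therefore estimated at 4.4, within 3.7 to 5.1, an expected step of a number 2.10 log units lower from compound 3 to compound 4 (beyond the scatter).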

Compound 4, partition coefficient: 4.05
Estimate against measurement, compound 4: 0.35 log units above, and the stated range covers the measured number.
By their numbers in this assay, from the lowest: compound 4; then compound 1; then compound 3; then compound 2.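

In this assay, among the compounds shown here, hydrogen in place of 3-methylbut-2-en-1-yl on a saturated chain carbon bound to a double-bonded chain carbon gives a number 2.45 log units lower from compound 3 to compound 4 (beyond the scatter), the first measured change at this place. On a saturated chain carbon, three bonds along the chain from an aromatic carbon, hydrogen in place of ethyl gives a number 1.40 log units lower from compound 1 to compound 4 (beyond the scatter), and hydrogen in place of pentyl gives a number 2.87 log units lower from compound 2 to compound 4 (beyond the scatter), so removing the longer group gives the larger fall. Nothing available explains these falls. As far as these compounds go, how an amine or a carboxylic acid at either place would read stays open.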